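Aromatase inhibition: prenyl moved from ring carbon to ether oxygen

This account rests on a few compounds, and the source may have more. Where it says the series, first, only, none or still open, it means among the compounds named here.

Measured so far:
compound 1 `COc1ccc2c(c1)OC(c1ccc(OC)c(CC=C(C)C)c1)CC2=O`, 3670 nM
compound 2 `COc1ccc(C2CC(=O)c3ccc(OC)cc3O2)cc1`, 1860 nM

In an assay on isolated protein for inhibition of Aromatase (Homo sapiens) (on this read-out lower numbers stand for stronger inhibition and higher numbers for weaker inhibition), compound 2 gives 1860 nM, and compound 1 gives 3670 nM; the step of a 2.0-fold lower number from compound 1 to compound 2 (0.30 log units; within the scatter) leaves the two within the scatter of each other, so neither is distinguished. Compound 3 `COc1ccc2c(c1)OC(c1ccc(OCC=C(C)C)cc1)CC2=O` differs from compound 2 by 2-methylprop-1-en-1-yl in place of hydrogen on a saturated chain carbon bound to an oxygen on an aromatic ring. Among the compounds with values here, the only measured step that bears on this change is the removal of the same chain from an aromatic carbon, a 2.0-fold lower number from compound 1 to compound 2 (0.30 log units; within the scatter), which was within the scatter. No step beyond the scatter is therefore expected in this assay for compound 3, whose value is estimated at 2500 nM (range 800 nM to 8000 nM), meaning an expected step of a 1.3-fold higher number from compound 2 to compound 3 (0.13 log units; within the scatter).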

Compound 3, half-maximal inhibitory concentration: 28700 nM
Compound 3: middle estimate off by 11-fold (1.06 log units), on the low side, and the stated range ends below it.
By their numbers in this assay, from the lowest: compounds 2 and 1 (each within the scatter of the next); then compound 3.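

Changing methoxy to (3-methylbut-2-en-1-yl)oxy weakens inhibition in this assay (a 15-fold higher number from compound 2 to compound 3 (1.19 log units; beyond the scatter)). This position on oxygen therefore responds to the added chain, whereas removing the same chain from an aromatic carbon stayed within the scatter (a 2.0-fold lower number from compound 1 to compound 2 (0.30 log units; within the scatter)). No available evidence explains this difference. 

On these data alone, whether the loss tracks chain length or the double bond stays open. Ethoxy and saturated 3-methylbutoxy at this oxygen would separate the two, and a hydroxyl there would show how inhibition responds with no chain at all.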